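Chain extension at the double-bonded nitrogen: compound 3

The source may report more compounds than this note shows. Statements on the series, on what has been measured and on what is new or still open speak of the compounds shown alone.

Among the compounds with values here, compound 1 `C/N=c1/c(C#N)c2n(c(=O)n1-c1ccccc1)CCC2` stands highest of the two numbers measured so far: in a functional assay on the whole organism (strain albino) for inhibition, with Rattus norvegicus as the target, read by paw edema, with a stated time of 4 h, at a dose of 0.029 mmol/kg by the oral route (on this read-out lower numbers stand for less inhibition and higher numbers for more inhibition at the one dose given (going by the name of the read-out)), compound 1 gives 34.8%. Compound 2 `C=CC/N=c1/c(C#N)c2n(c(=O)n1-c1ccccc1)CCC2` in this assay gives 14.3%, and the step of a number 20.5 percentage points lower from compound 1 to compound 2 (beyond the scatter) lies beyond the scatter. Compound 3 `CCCC/N=c1/c(C#N)c2n(c(=O)n1-c1ccccc1)CCC2` differs from compound 1 by propyl in place of hydrogen on a saturated chain carbon bound to a double-bonded nitrogen. Within the data shown here, the one measured step that bears on this change is the vinyl one, a modest drop at the same place, and a propyl there is expected to move the number in the same direction by a comparable amount. Compound 3 is therefore expected to give 16%, between 2% and 32%, a step of a number 18.8 percentage points lower from compound 1 to compound 3 (beyond the scatter).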

Compound 3, a percentage reported as inhibition, in the whole organism at one dose (the size of the read-out at that dose, not a potency): 22.4%
For compound 3 the middle estimate is 6.4 percentage points below the measured one, within the range that was stated.
By their numbers in this assay, from the lowest: compounds 2 and 3 (each within the scatter of the next); then compound 1.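

Going from methyl to butyl at this place costs activity in this assay: propyl in place of hydrogen on a saturated chain carbon bound to a double-bonded nitrogen gives a number 12.4 percentage points lower from compound 1 to compound 3 (beyond the scatter). So the drop is not confined to the vinyl group. Propyl in place of vinyl gives a number 8.1 percentage points higher from compound 2 to compound 3 (within the scatter), so compound 2 and compound 3 cannot be told apart here, and the saturated and unsaturated chains read alike.

Still open, going by these compounds, is whether a longer chain, or a chain ending in an amine or a carboxylic acid, would stay level with compound 3 or come closer to compound 1. No measurement shown explains the drop.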